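The source may report more compounds than this note shows. Statements on the series, on what has been measured and on what is new or still open speak of the compounds shown alone.

In an ADME assay on microsomes from liver (Mus musculus) for metabolic stability, read by LC-MS, with a stated time of 40 min, tested at 0.5 uM (a higher number here means faster removal of the compound, a lower number slower removal), compound 2 (`CC1(C)CCN(c2ncccc2C(=O)Nc2cccc(S(=O)(=O)C3CCCC3)c2)CC1`) gives > 399 mL.min-1.g-1, which is a limit of the assay and not a number. Compound 3 (`O=C(Nc1cccc(S(=O)(=O)C2CCCC2)c1)c1cccnc1N1CCC2(CC1)CC2`) differs from compound 2 in a single group, on an aromatic carbon of a six-membered aromatic ring with 1 nitrogen, next to the ring nitrogen: a group of 8 heavy atoms (7 carbon, 1 nitrogen; one three-membered non-aromatic ring of carbon only, one six-membered non-aromatic ring with 1 hetero atom) in place of a group of 8 heavy atoms (7 carbon, 1 nitrogen; one six-membered non-aromatic ring with 1 hetero atom), on an aromatic carbon. Within the data shown here, no measured pair of compounds shows this change, so the data offer no direct step for it.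

The nearest evidence is compound 1 (`CC(C)S(=O)(=O)c1cccc(NC(=O)c2cccnc2N2CCC3(CC2)CC3)c1`), which already carries the entering group. Compound 1 gives > 399 mL.min-1.g-1, again a limit. The two measured compounds therefore share (the limit of > 399 mL.min-1.g-1 in this assay, at which 2 of the 2 values shown sit), and neither has a number that could be compared with the other.

On this basis, no change beyond the scatter is expected in this assay, and compound 3 may well be reported only as a limit too. The expected step is a step that the limit leaves unreadable from compound 2 to compound 3, which would be no real shift in either direction. For compound 3 the estimated value is 450 mL.min-1.g-1, with an expected range from 280 mL.min-1.g-1 to 800 mL.min-1.g-1.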

Compound 3, intrinsic clearance in microsomes: > 399 mL.min-1.g-1
Compound 3: a limit, no number; the forecaster's own chance of this, stated with the estimate: 75%; the middle value lies beyond the limit too.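

In this assay compound 3 gives > 399 mL.min-1.g-1, which is a limit of the assay and not a number. Among these compounds, no step from compound 1 or compound 2 to compound 3 can be read. The compounds shown leave open whether 4,4-dimethylpiperidin-1-yl and the group replacing it, or isopropyl and cyclopentyl on the sulfonyl sulfur, differ at all in this assay.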